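The source may hold more compounds than are shown below. What is called first, only, known or untested is meant among the compounds shown, and "the series" means these compounds.

In a functional assay on RS4-11 cells (Homo sapiens) for inhibition, read by CCK-8 assay, with a stated time of 72 h (on this read-out lower numbers stand for stronger inhibition and higher numbers for weaker inhibition), compound 1 `CC1(C)CCC(CN2CCN(c3ccc(C(=O)NS(=O)(=O)c4ccc(NCC5CCOCC5)c([N+](=O)[O-])c4)c(Oc4cnc5[nH]ccc5c4)c3)CC2)=C(c2ccc(Cl)cc2C(F)(F)F)C1` gives 74 nM and compound 2 `CC1(C)CCC(CN2CCN(c3ccc(C(=O)NS(=O)(=O)c4ccc(NCC5CCOCC5)c([N+](=O)[O-])c4)c(Oc4cnc5[nH]ccc5c4)c3)CC2)=C(c2ccc(C(F)(F)F)cc2)C1` gives 6.2 nM, the lower of the two numbers. For the measured compounds named here, the only measured step, a 12-fold lower number from compound 1 to compound 2 (1.08 log units; beyond the scatter), is large but lies at a different place, on a double-bonded ring carbon. Compound 3 `CN(C)CCCNc1ccc(S(=O)(=O)NC(=O)c2ccc(N3CCN(CC4=C(c5ccc(C(F)(F)F)cc5)CC(C)(C)CC4)CC3)cc2Oc2cnc3[nH]ccc3c2)cc1[N+](=O)[O-]` differs from compound 2 by 2-(dimethylamino)ethyl in place of oxan-4-yl on a saturated chain carbon bound to a nitrogen on an aromatic ring, with 2-(dimethylamino)ethyl in place of oxan-4-yl on a saturated chain carbon bound to a nitrogen on an aromatic ring. Going by the values given here, no measured step covers this change, so no step beyond the scatter is expected in this assay, though this expectation is loosely founded. The estimated change is a 1.3-fold higher number from compound 2 to compound 3 (0.11 log units; within the scatter). The estimated value for compound 3 is 8 nM, within a range of 2.5 nM to 30 nM.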

Compound 3, half-maximal inhibitory concentration: 3.9 nM
For compound 3 the middle estimate is 2.1-fold (0.31 log units) above the measured one; the range from low to high includes it.
By their numbers in this assay, from the lowest: compounds 3 and 2 (each within the scatter of the next); then compound 1.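

In this assay, replacing (oxan-4-yl)methyl with 3-(dimethylamino)propyl gives a 1.6-fold lower number from compound 2 to compound 3 (0.20 log units; within the scatter) and so leaves the number within the scatter. On this read-out, the position on a saturated chain carbon bound to a nitrogen on an aromatic ring therefore accepts an open chain ending in an amine as well as the oxan-4-yl ring. No evidence explains why the two groups read alike. Still open, on these data alone, is how a carboxylic acid at the end of this chain would read. As far as these compounds go, a longer chain or a primary amine in place of the dimethylamino group also remains open.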